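The source may hold more compounds than are shown below. What is called first, only, known or untested is meant among the compounds shown, and "the series" means these compounds.

Compound 1 `Oc1cccc(-c2cc(-c3ccccc3)cc(-c3ccco3)n2)c1` and compound 2 `Oc1cccc(-c2cc(-c3ccccc3)cc(-c3ccncc3)n2)c1` share one core, while compound 3 `Oc1ccc(-c2cc(-c3ccccc3)nc(-c3ccco3)c2)cc1` is made of the same atoms joined differently; the difference between the two cores is not broken down here. In a functional assay on HCT-15 cells (Homo sapiens) for cytotoxicity, read by ELISA, with a stated time of 2 days (on this read-out lower numbers stand for stronger inhibition and higher numbers for weaker inhibition), compound 1 gives 13500 nM, and compound 2 gives 27400 nM. The change pyridin-4-yl in place of furan-2-yl on an aromatic carbon made a 2.0-fold higher number from compound 1 to compound 2 (0.31 log units; beyond the scatter). In this assay compound 3 gives 5100 nM, the lowest of the three numbers. Compound 4 `Oc1ccc(-c2cc(-c3ccccc3)nc(-c3ccncc3)c2)cc1` is not yet measured; it differs from compound 3 by pyridin-4-yl in place of furan-2-yl on an aromatic carbon. Going by the values given here, this is the same kind of change as the one from compound 1 to compound 2, though the place differs: in compound 3 it is meta to a 4-hydroxyphenyl group, in compound 1 meta to a 3-hydroxyphenyl group. The expected step is a 2.0-fold higher number from compound 3 to compound 4 (0.29 log units; within the scatter), resting on the step of a 2.0-fold higher number from compound 1 to compound 2 (0.31 log units; beyond the scatter) for the same kind of change. Compound 4 is therefore estimated to give about 10000 nM in this assay, from 5000 nM to 22000 nM.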

Compound 4, half-maximal inhibitory concentration: 11700 nM
For compound 4 the middle estimate is 1.2-fold (0.07 log units) below the measured one; the range from low to high includes it.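

In this assay, pyridin-4-yl in place of furan-2-yl gave a 2.3-fold higher number from compound 3 to compound 4 (0.36 log units; beyond the scatter), and the step kept much the same size on the two cores: the same change on two cores in this assay, a 2.0-fold higher number (0.31 log units; beyond the scatter) from compound 1 to compound 2 and a 2.3-fold higher number (0.36 log units; beyond the scatter) from compound 3 to compound 4, 1.1-fold (0.05 log units) apart, within the scatter of two such steps. Across these two cores, then, the change moves the number in the same direction and by a like amount. Going by these compounds alone, this rests on only two pairs in this assay, and it shows neither why the steps agree nor that the change would carry over to any further core.

The compounds shown leave open how an amine or a carboxylic acid would behave in place of the furan-2-yl or pyridin-4-yl group. They also leave open whether the step would survive if a longer chain stood in place of the phenyl group.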